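The compounds below may be only part of what the source reports. "The series", "measured", "known", "first", "only" and "open" are said of these compounds alone.

Measured in a functional assay on WM 266-4 cells (Homo sapiens) for antiproliferative activity, read by MTT assay, with a stated time of 24 h; on this read-out higher numbers stand for weaker inhibition of growth and lower numbers for stronger inhibition of growth:
- Compound 1 `O=C(c1cncc(Br)c1)N1N=C(c2ccc(Cl)cc2)CC1c1ccc(Cl)cc1`: 6090 nM
- Compound 2 `O=C(c1cccnc1Cl)N1N=C(c2ccc(Cl)cc2)CC1c1ccc(Cl)cc1`: 3580 nM
- Compound 3 `O=C(c1cncc(Br)c1)N1N=C(c2ccc(Cl)cc2)CC1c1ccc(Br)cc1`: 8010 nM

In this assay compound 3, at 8010 nM, lies within the scatter of compound 1, while its number is higher than that of compound 2, a gap beyond the scatter. Compound 4 `O=C(c1cccnc1Cl)N1N=C(c2ccc(Cl)cc2)CC1c1ccc(Br)cc1` differs from compound 3 in one place: 2-chloropyridin-3-yl in place of 5-bromopyridin-3-yl on a carbonyl carbon. The same exchange was already measured on the core of compound 1, as a 1.7-fold lower number from compound 1 to compound 2 (0.23 log units; within the scatter). The bromo in place of chloro on an aromatic carbon, a 1.3-fold higher number from compound 1 to compound 3 (0.12 log units; within the scatter), links the two pairs. Both steps lie within the scatter. A similar small step toward a lower number, not clearly beyond the scatter, is therefore expected: a 1.7-fold lower number from compound 3 to compound 4 (0.23 log units; within the scatter). Compound 4 is estimated at 4700 nM, with an expected range of 2700 nM to 8200 nM.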

Compound 4, concentration for 50% growth inhibition: 7450 nM
Compound 4: the middle estimate sits 1.6-fold (0.20 log units) below what was measured; the measured number falls inside the stated range.
By their numbers in this assay, from the lowest: compounds 2, 1, 4 and 3 (each within the scatter of the next, the first and the last beyond it).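

On the core of compound 3, 2-chloropyridin-3-yl in place of 5-bromopyridin-3-yl on a carbonyl carbon gives a 1.1-fold lower number from compound 3 to compound 4 (0.03 log units; within the scatter), so in this assay this exchange stays within the scatter on both cores: the same change on two cores in this assay, a 1.7-fold lower number (0.23 log units; within the scatter) from compound 1 to compound 2 and a 1.1-fold lower number (0.03 log units; within the scatter) from compound 3 to compound 4, 1.6-fold (0.20 log units) apart, within the scatter of two such steps

The bromo in place of chloro on an aromatic carbon now gives a 2.1-fold higher number from compound 2 to compound 4 (0.32 log units; beyond the scatter), its first step beyond the scatter, though this step is not clearly separated from the one seen on the other core: the same change on two cores in this assay, a 1.3-fold higher number (0.12 log units; within the scatter) from compound 1 to compound 3 and a 2.1-fold higher number (0.32 log units; beyond the scatter) from compound 2 to compound 4, 1.6-fold (0.20 log units) apart, within the scatter of two such steps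

The compounds shown leave open whether an amine or a carboxylic acid in place of the bromo on the 5-bromopyridin-3-yl group would move the number beyond the scatter.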